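Fluoro substitution on the aryl ring of compound 1

The source may report more compounds than this note shows. Statements on the series, on what has been measured and on what is new or still open speak of the compounds shown alone.

The series shares the core of compound 1 `Brc1cccc2c1nnn2CC1CC1`, which in an ADME assay on microsomes from liver (Rattus norvegicus, strain Wistar) for metabolic stability, tested at 2.5 uM (on this read-out higher numbers stand for fast clearance and lower numbers for slow clearance), gives 0.6 mL/min/g. Compound 2 `CCCn1nnc2c(Br)cccc21` gives 0.8 mL/min/g in this assay; the step of a 1.3-fold higher number from compound 1 to compound 2 (0.12 log units; within the scatter), from ethyl in place of cyclopropyl on a saturated chain carbon bound to an aromatic nitrogen, lies within the scatter, so the two compounds cannot be told apart. Compound 3 `CCn1nnc2c(Br)cccc21` has "not determined" (no result reported) in this assay. Compound 1 thus sits among two numbers that the scatter does not separate.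

Compound 4 `Fc1cc(Br)c2nnn(CC3CC3)c2c1` differs from compound 1 by fluoro in place of hydrogen on an aromatic carbon. Going by the values given here, no measured step touches that aromatic carbon or any position on the six-membered ring; the single measured step concerns the chain on the nitrogen and was itself within the scatter. Nothing in the measured set therefore points to a step in this assay in either direction, and a change within the scatter is expected, no change at the digits printed from compound 1 to compound 4 (within the scatter). Compound 4 is estimated at 0.6 mL/min/g in this assay, within 0.3 mL/min/g to 1.2 mL/min/g.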

Compound 4, intrinsic clearance in a liver preparation (reported as CLH), per the amount of preparation that the assay uses: 0.5 mL/min/g
The estimate for compound 4 lay 1.2-fold (0.08 log units) above the measured number; the range from low to high includes it.
By their numbers in this assay, from the lowest: compounds 4, 1 and 2 (each within the scatter of the next).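

In this assay, going by these compounds alone, the step of a 1.2-fold lower number from compound 1 to compound 4 (0.08 log units; within the scatter) gives the first reading for a change on the six-membered aromatic ring of the series, at the aromatic carbon meta to a bromo group. Up to now, the only step read concerned the chain on the nitrogen; this one shows that fluoro in place of hydrogen at this carbon also stays within the scatter, so compound 4 and compound 1 cannot be told apart on this read-out. Nothing at hand gives a reason for this result.

On these data alone, whether trifluoromethyl, methoxy or an amine at this same carbon would move the number beyond the scatter remains open. Also open, as far as these compounds go, is how fluoro behaves on the other carbons of the ring, and what happens when nitrile takes the place of the bromo group.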